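The source may hold more compounds than are shown below. What is called first, only, known or untested is meant among the compounds shown, and "the series" means these compounds.

Compound 1 `Fc1ccc(-c2noc3c2CCNCC3)cc1`: > 10000 nM
Compound 2 `Cc1ccc(-c2n[nH]c3c2CCNCC3)cc1`: 165 nM

Both measured compounds were tested in an assay on cells for displacement of a labelled ligand from 5-hydroxytryptamine receptor 1D (Homo sapiens), read by scintillation counting, with a stated time of 1.5 h; a higher number here means a weaker inhibitor, a lower number a stronger inhibitor. Compound 1 gives only > 10000 nM, which is a limit of this assay rather than a number (the limit of > 10000 nM in this assay, at which 1 of the 2 values shown sits). Among the compounds with values here, compound 2 gives 165 nM, the only real number among the results, so it cannot be ranked against any other measured compound. Compound 1 and compound 2 differ from each other in more than one place, so no single step can be read from the pair.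

Within the data shown here, compound 3 `Fc1ccc(-c2n[nH]c3c2CCNCC3)cc1` keeps the core of compound 2 and changes only one group on the six-membered aromatic ring of carbon only: fluoro in place of methyl on an aromatic carbon. Among the measured compounds shown here, no measured pair shows this change on its own, so the size of the step in this assay cannot be taken from the data. Such a single-group swap is expected to shift the inhibition constant little, if at all beyond the scatter, leaving compound 3 close to compound 2. Compound 3 is therefore expected at 250 nM, with a range from 80 nM to 900 nM. The expected step is a 1.5-fold higher number from compound 2 to compound 3 (0.18 log units; within the scatter).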

Compound 3, inhibition constant: 636 nM
The estimate for compound 3 lay 2.5-fold (0.41 log units) below the measured number; the measured number falls inside the stated range.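

Within the data shown here, this is the first step in this assay that can be read as a number: fluoro in place of methyl on the aromatic carbon, para to a large group, gives a 3.9-fold higher number from compound 2 to compound 3 (0.59 log units; beyond the scatter), with the methyl compound the stronger inhibitor of the pair. The position therefore responds to the group it carries, even though methyl and fluoro each count as one heavy atom, with no hydrogen-bond donors or acceptors and no net charge. Steps involving compound 1 cannot be read, as its value is a limit of the assay and not a number: the limit of > 10000 nM in this assay, at which 1 of the 3 values shown sits.

What the compounds shown leave open is how other groups at this position would fare, for example whether chlorine, methoxy or a longer chain such as ethyl would sit nearer to compound 2 or to compound 3, or move further from both. The step also rests on a single pair, and whether the same swap gives a step of similar size on a different core remains an open question.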